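The source may hold more compounds than are shown below. What is called first, only, known or untested is meant among the compounds shown, and "the series" means these compounds.

Measured compounds, in a functional assay on DU-145 cells (Homo sapiens) for inhibition, read by trypan blue exclusion, with a stated time of 72 h; a higher number here means a weaker inhibitor, a lower number a stronger inhibitor:

compound 1, `Cn1c(=O)c(S(=O)(=O)Cc2ccc(F)cc2)cc2cnc(Nc3ccc4[nH]ccc4c3)nc21`, gives 30000 nM
compound 2, `COc1ccc(Nc2ncc3cc(S(=O)(=O)c4ccc(Cl)cc4)c(=O)n(C)c3n2)cc1`, gives 30000 nM
compound 3, `Cn1c(=O)c(S(=O)(=O)c2ccc(F)cc2F)cc2cnc(Nc3ccc4cccc(O)c4n3)nc21`, gives 5000 nM

Compound 1 stands level with compound 2 at the digits shown, the two of them sharing the highest number of the three; compound 3 sits well below both, a gap that lies beyond the scatter. No two of the measured compounds differ in only one place, so no single change can be read off for its own effect.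

Compound 4, `Cn1c(=O)c(S(=O)(=O)c2ccc(Br)cc2)cc2cnc(Nc3ccc4[nH]ccc4c3)nc21`, is the next compound to be run in this assay. It differs from compound 1 in one place: 4-bromophenyl in place of 4-fluorobenzyl on a sulfonyl sulfur. Compound 2 and compound 3 also carry an aryl group on the sulfonyl sulfur, yet they are far apart in this assay, and each differs from compound 1 at the amine as well. With nothing to anchor the change, the expectation for compound 4 is a step from compound 1 of a 1.5-fold lower number from compound 1 to compound 4 (0.18 log units; within the scatter), not clearly beyond the scatter in either direction. Compound 4 is therefore estimated at 20000 nM, with a range from 5000 nM to 50000 nM.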

Compound 4, half-maximal inhibitory concentration: 5000 nM
Beside the measured number, compound 4's estimate is 4.0-fold (0.60 log units) above it; low and high end bracket the measured number.
By their numbers in this assay, from the lowest: compounds 3 and 4 (each within the scatter of the next); then compounds 1 and 2 (each within the scatter of the next).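

In this assay, 4-bromophenyl in place of 4-fluorobenzyl on a sulfonyl sulfur gives a 6.0-fold lower number from compound 1 to compound 4 (0.78 log units; beyond the scatter). Among the compounds shown here, this is the first comparison with only one place changed, and it shows that the group on the sulfonyl sulfur can by itself move the number beyond the scatter while the rest of the molecule stays fixed. No measurement in hand bears on why this change has this effect.

The change alters both the halogen and the link to the ring, so a fluorophenyl or a bromobenzyl group on the sulfonyl sulfur would be needed to separate the two. Going by these compounds, whether the step holds with a different amine on the shared core, such as the anisidine of compound 2, also remains open.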